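A few compounds are considered here, and "the series" means these few. Any claim that something is new, unique, unknown or untested is made for them only; others in the source may bear on it.

Compound 1 `CN(C)c1ccc(NC(=O)c2csc(Cc3c(Cl)cccc3Cl)n2)cc1` — 1270 nM
Compound 2 `O=C(Nc1ccc(C(F)(F)F)cc1)c1csc(Cc2c(Cl)cccc2Cl)n1` — 88 nM

In an assay on CHO cells, read by calcium flux (on this read-out higher numbers stand for weaker inhibition and lower numbers for stronger inhibition), compound 2 stands lowest of the two numbers shown; its nearest neighbour is compound 1, and the gap between them is a 14-fold lower number from compound 1 to compound 2 (1.16 log units; beyond the scatter). Compound 3 `O=C(Nc1ccc(C(F)(F)F)cc1)c1csc(-c2c(Cl)cccc2Cl)n1` has not yet been measured in this assay. It differs from compound 2 in one place: 2,6-dichlorophenyl in place of 2,6-dichlorobenzyl on an aromatic carbon. Going by the values given here, no measured step bears on this change. The single step shown, a 14-fold lower number from compound 1 to compound 2 (1.16 log units; beyond the scatter), concerns the group on the other aromatic ring and says nothing about the link between the five-membered ring and the dichlorinated ring. Among the compounds with values here, with no precedent either way, the account expects no step beyond the scatter in this assay, the direction being open. On that basis compound 3 is estimated at 120 nM with a range of 30 nM to 500 nM. That estimate amounts to an expected 1.4-fold higher number from compound 2 to compound 3 (0.13 log units; within the scatter).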

Compound 3, half-maximal inhibitory concentration: > 4000 nM
Compound 3: only a limit was reported (the forecaster's own chance of this, stated with the estimate: 5%); middle value at least 33-fold (1.52 log units) away from the limit.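

In this assay, the link between the five-membered ring and the dichlorinated ring turns out to count for a great deal: with 2,6-dichlorophenyl in place of 2,6-dichlorobenzyl, the record shows an at least 45-fold higher number from compound 2 to compound 3 (1.65 log units; beyond the scatter), a step beyond the scatter. Compound 3 carries only a limit of the assay, not a number: the limit of > 4000 nM in this assay, at which 1 of the 3 values shown sits. The earlier pair changed only the group on the other aromatic ring, whereas this step shows that the aromatic carbon next to the ring nitrogen and next to the ring sulfur does not tolerate this exchange.

The compounds shown leave open whether a longer chain, an ether oxygen or an amine nitrogen as the link would hold the number of compound 2. They also leave open how far compound 3 lies past its limit, and whether the same exchange would act alike with the dimethylamino group of compound 1.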